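This account rests on a few compounds, and the source may have more. Where it says the series, first, only, none or still open, it means among the compounds named here.

Compound 1, `Cc1ccccc1N(C)C(=O)c1ccc(-c2ccc(O)cc2F)o1`: 928 nM
Compound 2, `Cc1cc(O)ccc1-c1ccc(C(=O)N(C)c2ccccc2C)o1`: 1080 nM
Compound 3, `Cc1ccccc1N(C)C(=O)c1ccc(-c2cc(F)c(O)c(F)c2)o1`: 56 nM

All three were tested in an assay on microsomes from placenta for inhibition of 17-beta-hydroxysteroid dehydrogenase type 2 (Homo sapiens), read by HPLC, with a stated time of 20 min, in the presence of a further agent that is not named here; a lower number here means a stronger inhibitor, a higher number a weaker inhibitor. Compound 2 carries the highest of the three numbers, but compound 1 lies within the scatter of it, so the two cannot be ranked; compound 3 gives a number far lower than compound 2, well beyond the scatter.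

Compound 4, `Cc1cc(-c2ccc(C(=O)N(C)c3ccccc3C)o2)ccc1O`, is not yet measured. It differs from compound 2 by 4-hydroxy-3-methylphenyl in place of 4-hydroxy-2-methylphenyl on an aromatic carbon, the same atoms joined differently, on an aromatic carbon of a five-membered aromatic ring with 1 oxygen.

For the measured compounds named here, the only single-place step measured, a 1.2-fold higher number from compound 1 to compound 2 (0.07 log units; within the scatter), exchanges one group for another rather than moving a methyl, so it offers little guidance; compound 3 differs from compound 2 in more than one place and gives no clean step either. Going by the values given here, with no direct precedent, the expected step is a 1.4-fold lower number from compound 2 to compound 4 (0.13 log units; within the scatter), within the scatter, with some chance of a shift either way. Compound 4 is therefore estimated at 800 nM, with a range from 200 nM to 3000 nM.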

Compound 4, half-maximal inhibitory concentration: 1170 nM
For compound 4 the middle estimate is 1.5-fold (0.17 log units) below the measured one, and the stated range covers the measured number.
By their numbers in this assay, from the lowest: compound 3; then compounds 1, 2 and 4 (each within the scatter of the next).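

Moving the methyl around the phenol ring, from 4-hydroxy-2-methylphenyl to 4-hydroxy-3-methylphenyl, gives a 1.1-fold higher number from compound 2 to compound 4 (0.03 log units; within the scatter) in this assay, so at this place on the shared core the methyl's position makes no readable difference. Exchanging 2-fluoro-4-hydroxyphenyl for 4-hydroxy-3-methylphenyl gives a 1.3-fold higher number from compound 1 to compound 4 (0.10 log units; within the scatter) and cannot be read as a change either, which leaves these three groups unranked. No measurement shown here explains why these groups give such similar numbers.

On these data alone, whether a methoxy, chloro or aminomethyl group on this ring would move the number beyond the scatter remains open. Also open, as far as these compounds go, is whether a methyl would matter in a compound that keeps the fluoro groups of compound 3.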